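The compounds below may be only part of what the source reports. "The series", "measured", "known", "first", "only" and "open" are said of these compounds alone.

In a functional assay on MDA-MB-231 cells (Homo sapiens) for antiproliferative activity, read by MTT assay, with a stated time of 6 days (on this read-out lower numbers stand for stronger inhibition and higher numbers for weaker inhibition), compound 1 (`CC(=O)O[C@@H]1C=CC(=O)O[C@@H]1[C@@H](COC(=O)c1ccc(Cl)cc1)OC(C)=O`) gives 1850 nM. Compound 3 (`O=C1C=C[C@@H](OCc2ccccc2)[C@@H]([C@@H](COC(=O)/C=C/c2ccc([N+](=O)[O-])cc2)OCc2ccccc2)O1`) gives 1550 nM, a gap within the scatter, while compound 2 (`O=C1C=C[C@@H](OCc2ccccc2)[C@@H]([C@@H](COC(=O)/C=C/c2ccccc2)OCc2ccccc2)O1`) gives 4970 nM, a higher number and beyond the scatter.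

Compound 4 (`CC(=O)O[C@@H]1C=CC(=O)O[C@@H]1[C@@H](COC(=O)/C=C/c1ccc(F)cc1)OC(C)=O`) differs from compound 1 in one place: 2-(4-fluorophenyl)ethenyl in place of 4-chlorophenyl on a carbonyl carbon. In words, this is 2-(4-fluorophenyl)ethenyl in place of 4-chlorophenyl on a carbonyl carbon.

Among the compounds with values here, no measured step makes this exchange directly. The closest evidence is a 3.2-fold lower number from compound 2 to compound 3 (0.51 log units; beyond the scatter), a modest step that comes from nitro in place of hydrogen on an aromatic carbon. It shows that one change on an aromatic ring can shift the numbers in this assay beyond the scatter. However, compound 2 and compound 3 also differ from compound 4 elsewhere on the core, so they give no reliable direction. No step beyond the scatter is therefore expected, and the estimated change is a 1.1-fold higher number from compound 1 to compound 4 (0.03 log units; within the scatter). For compound 4 the estimated value is 2000 nM, with an expected range from 650 nM to 6000 nM.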

Compound 4, half-maximal inhibitory concentration: 34400 nM
Beside the measured number, compound 4's estimate is 17-fold (1.24 log units) below it, and the stated range ends below it.
By their numbers in this assay, from the lowest: compounds 3 and 1 (each within the scatter of the next); then compound 2; then compound 4.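

On a carbonyl carbon whose other neighbours are oxygen next to a carbonyl group, putting 2-(4-fluorophenyl)ethenyl in place of 4-chlorophenyl gives a 19-fold higher number from compound 1 to compound 4 (1.27 log units; beyond the scatter) in this assay. Within the data shown here, the only earlier step, a 3.2-fold lower number from compound 2 to compound 3 (0.51 log units; beyond the scatter), was a modest one, whereas this large step shows that the group on this carbonyl carbon can move the number strongly while the rest of compound 1 stays the same. No available evidence explains this shift.

The exchange alters two things together, adding the ethenyl link and replacing chlorine with fluorine, so the compounds shown cannot divide the step between them. Either 4-fluorophenyl or 2-(4-chlorophenyl)ethenyl at this position, on the core of compound 1, would change only one of the two.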